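Series notes: cyano for benzoyl at the sulfonyl-bearing alkene carbon

This account rests on a few compounds, and the source may have more. Where it says the series, first, only, none or still open, it means among the compounds named here.

Measured compounds:
Compound 1, `CC(=O)/C(=C\c1c(-c2ccccc2)[nH]c2ccccc12)S(=O)(=O)c1ccccc1`, in a functional assay on NCI-H23 cells (Homo sapiens) for inhibition, read by sulforhodamine B assay, with a stated time of 48 h; a lower number here means a stronger inhibitor of growth, a higher number a weaker inhibitor of growth: compound 1 gives 1600 nM.
Compound 2, `O=C(/C(=C\c1c(-c2ccccc2)[nH]c2ccccc12)S(=O)(=O)c1ccccc1)c1ccccc1`, in this assay: compound 2 gives 9600 nM.

Compound 2 stands at the highest of the two numbers, its nearest neighbour being compound 1 a step away a 6.0-fold higher number from compound 1 to compound 2 (0.78 log units; beyond the scatter). Within the data shown here, the single measured step in the pair is that one, phenyl in place of methyl on the carbonyl carbon, and it moved the number up beyond the scatter.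

Compound 3, `N#C/C(=C\c1c(-c2ccccc2)[nH]c2ccccc12)S(=O)(=O)c1ccccc1`, is not yet measured. It differs from compound 2 thus: cyano in place of benzoyl on a double-bonded chain carbon bound to a double-bonded chain carbon and a sulfonyl sulfur. Among the measured compounds shown here, no measured step covers cyano directly. For the measured compounds named here, the only bearing evidence is that the step from compound 1 to compound 2, which brought in the six-membered ring now removed again, raised the number; removing the benzoyl group in favour of a two-atom cyano group is therefore expected to pull the number back down in this assay, toward where compound 1 stands, though with wide uncertainty because the cyano is unlike either carbonyl group. Compound 3 is expected at 2500 nM, range 700 nM to 9000 nM, a step of a 3.8-fold lower number from compound 2 to compound 3 (0.58 log units; beyond the scatter).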

Compound 3, concentration for 50% growth inhibition: 4700 nM
Estimate against measurement, compound 3: 1.9-fold (0.27 log units) below; low and high end bracket the measured number.
By their numbers in this assay, from the lowest: compound 1; then compound 3; then compound 2.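

At the double-bonded chain carbon bound to a double-bonded chain carbon and a sulfonyl sulfur, replacing benzoyl with cyano gives in this assay a 2.0-fold lower number from compound 2 to compound 3 (0.31 log units; beyond the scatter), while replacing acetyl with cyano gives a 2.9-fold higher number from compound 1 to compound 3 (0.47 log units; beyond the scatter), so the three groups run acetyl, cyano, benzoyl from the lowest number to the highest. Taking the six-membered aromatic ring away from this place therefore recovers only part of the rise seen with benzoyl, and the ring-free cyano compound stays above the acetyl compound, which also has no ring at this carbon. Nothing available explains why the cyano group falls at this point in the order.

Three groups at one carbon cannot show whether the carbonyl of the acetyl group is what gives compound 1 the lowest number, and a methyl ester or a primary amide at the same carbon would bear directly on that question. As far as these compounds go, it also remains open whether a longer chain, such as propanoyl, would stay near acetyl or move toward benzoyl in this assay.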